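Series notes: phenoxy in place of cyano

The source may hold more compounds than are shown below. What is called first, only, known or untested is meant among the compounds shown, and "the series" means these compounds.

Three measured compounds share one core and differ only in the group on an aromatic carbon. Compound 1 `O=C(O)CCc1ccc(NCc2ccc(Cl)cc2)cc1` gives 111% in a functional assay on CHO cells for agonist activity at Free fatty acid receptor 1 (Homo sapiens), read by reporter gene assay; a higher number here means a larger maximal response, a lower number a smaller maximal response. Compound 2 `Cc1ccc(CNc2ccc(CCC(=O)O)cc2)cc1` gives 152%, and compound 3 `N#Cc1ccc(CNc2ccc(CCC(=O)O)cc2)cc1` gives 49%. Compound 3 stands lowest of the three; its nearest neighbour is compound 1, and the widest gap is to compound 2. The two steps that lead to it are both large: a number 62 percentage points lower from compound 1 to compound 3 (beyond the scatter) and a number 103 percentage points lower from compound 2 to compound 3 (beyond the scatter). The step from compound 1 to compound 2, a number 41 percentage points higher from compound 1 to compound 2 (beyond the scatter), shows that the substituent here moves the maximal response strongly in both directions.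

Compound 4 `O=C(O)CCc1ccc(NCc2ccc(Oc3ccccc3)cc2)cc1` is not yet measured. It differs from compound 3 in one place: phenoxy in place of cyano on an aromatic carbon. Among the measured compounds shown here, no measured step carries a phenoxy group, so the direction can only be read from the fact that the cyano-bearing compound 3 sits at the bottom. Replacing that group is therefore expected to raise the response, with a step of roughly a number 66 percentage points higher from compound 3 to compound 4 (beyond the scatter), though the size is uncertain. Compound 4 is estimated at 115%, within a range from 65% to 165%.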

Compound 4, largest response reached (reported as percent of maximum), in percent of the reference or control that the assay uses: 139%
For compound 4 the middle estimate is 24 percentage points below the measured one, and the stated range covers the measured number.
By their numbers in this assay, from the lowest: compound 3; then compound 1; then compound 4; then compound 2.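

In this assay, among the compounds shown here, this position tolerates a much larger group than the earlier compounds carried: phenoxy, with its seven heavy atoms and six-membered aromatic ring, retains a high maximal response (steps: a number 90 percentage points higher from compound 3 to compound 4 (beyond the scatter); a number 28 percentage points higher from compound 1 to compound 4 (beyond the scatter)). The largest group shown still does not give the highest number (step: a number 13 percentage points lower from compound 2 to compound 4 (beyond the scatter)), so the response does not simply rise with group size across these four compounds, and compound 2 with its methyl stays on top. No evidence is available to explain these differences at this position.

The compounds shown leave open whether the oxygen of phenoxy matters, which a directly attached phenyl or a benzyl group on the same carbon would test. They also leave open how a methoxy or an amine group would behave here.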